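Replacing an ester by hydroxymethyl on a fused core

The compounds below may be only part of what the source reports. "The series", "measured", "known", "first", "only" and "open" are said of these compounds alone.

Measured so far:
compound 1 `COc1cc(/C=C/C=C/c2nc3ccccc3o2)ccc1O`: 330 nM
compound 2 `CCOC(=O)c1ccc2oc(/C=C/C=C/c3ccc(O)c(OC)c3)nc2c1`: 250 nM
compound 3 `CCOC(=O)c1ccc2nc(/C=C/C=C/c3ccc(O)c(OC)c3)oc2c1`: 130 nM

In an assay on RBL-1 cells for inhibition of Polyunsaturated fatty acid 5-lipoxygenase (Rattus norvegicus) (a higher number here means a weaker inhibitor, a lower number a stronger inhibitor), compound 3 has the lowest number of the three. Its nearest neighbour is compound 2, whose value in this assay is within the scatter of that of compound 3; compound 1 stands furthest away, with a 2.5-fold lower number from compound 1 to compound 3 (0.40 log units; beyond the scatter).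

Compound 4 `COc1cc(/C=C/C=C/c2nc3ccc(CO)cc3o2)ccc1O` has not yet been measured. It differs from compound 3 by hydroxymethyl in place of ethoxycarbonyl on an aromatic carbon. Going by the values given here, the only step that speaks to this site is a 2.5-fold lower number from compound 1 to compound 3 (0.40 log units; beyond the scatter), which shows that putting an ethoxycarbonyl on the bare core gave a modest gain; the related step of a 1.3-fold lower number from compound 1 to compound 2 (0.12 log units; within the scatter) stayed within the scatter. Nothing shows what a hydroxymethyl does there, so the most that can be said is that compound 4 should land between compound 1 and compound 3, most likely a little above compound 3. The expected step is therefore a 1.7-fold higher number from compound 3 to compound 4 (0.23 log units; within the scatter). Compound 4 is expected to give 220 nM, with a range from 100 nM to 500 nM.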

Compound 4, half-maximal inhibitory concentration: 300 nM
Compound 4: the middle estimate sits 1.4-fold (0.13 log units) below what was measured, within the range that was stated.
By their numbers in this assay, from the lowest: compounds 3, 2, 4 and 1 (each within the scatter of the next, the first and the last beyond it).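

In this assay, exchanging ethoxycarbonyl for hydroxymethyl carries a real but modest cost (a 2.3-fold higher number from compound 3 to compound 4 (0.36 log units; beyond the scatter)). Measured against the bare core, hydroxymethyl gives no change that can be told from the scatter (a 1.1-fold lower number from compound 1 to compound 4 (0.04 log units; within the scatter)), so at this place on the ring the gain seen with ethoxycarbonyl does not carry over to the smaller group, and a substituent here does not by itself give a gain. No evidence is available on what lies behind this difference between the two groups.

On these data alone, it remains open whether a carboxylic acid, an amine or a longer chain at this place would match ethoxycarbonyl, stay level with the bare core, or do something else. The same exchange of ethoxycarbonyl for hydroxymethyl on compound 2 is also an open question.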